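The source may hold more compounds than are shown below. What is called first, only, known or untested is meant among the compounds shown, and "the series" means these compounds.

Compound 1 `O=C(Nc1ccc(S(=O)(=O)NC2CCCCC2)c2ccccc12)c1ccccc1` and compound 2 `Cc1ccccc1C(=O)Nc1ccc(S(=O)(=O)NC2CCN(C(=O)CO)CC2)c2ccccc12` share a core. In an assay on L1.2 cells for binding affinity to C-C chemokine receptor type 8 (Homo sapiens) (a higher number here means a weaker inhibitor, a lower number a stronger inhibitor), compound 1 gives 4.4 nM, and compound 2 gives 5.4 nM; the two values lie within the usual scatter of each other, so neither stands apart. Compound 3 `Cc1ccccc1C(=O)Nc1ccc(S(=O)(=O)NC2CCN(C(=O)N3CCC3)CC2)c2ccccc12` differs from compound 2 in one place: azetidin-1-yl in place of hydroxymethyl on a carbonyl carbon. Among the compounds with values here, no measured pair shows this change, and its size here has no precedent. For compound 3 the expected step in this assay is a 1.1-fold higher number from compound 2 to compound 3 (0.05 log units; within the scatter), staying within the scatter. Compound 3 is therefore estimated at 6 nM, with a likely range from 2 nM to 18 nM.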

Compound 3, inhibition constant: 3.5 nM
Estimate against measurement, compound 3: 1.7-fold (0.23 log units) above, within the range that was stated.
By their numbers in this assay, from the lowest: compounds 3, 1 and 2 (each within the scatter of the next).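

Putting azetidin-1-yl in place of hydroxymethyl on this carbonyl carbon gives, in this assay, a 1.5-fold lower number from compound 2 to compound 3 (0.19 log units; within the scatter). The hydroxymethyl group, with its hydrogen-bond donor and acceptor, can therefore give way to a four-membered ring with neither, and the number stays within the scatter. Nothing available explains this tolerance.

As far as these compounds go, whether it extends to other groups on this carbonyl carbon remains open, for example a carboxylic acid, a dimethylamino group or a longer chain such as hydroxypropyl. A larger ring, such as piperidin-1-yl, is equally untested by the compounds shown.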